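The compounds below may be only part of what the source reports. "The series", "measured", "known", "first", "only" and "open" are said of these compounds alone.

Three compounds share one core and differ only in the halogen on an aromatic carbon. Compound 1 `NC1CC(n2cc(I)c(=O)[nH]c2=O)OC1CO` carries iodo. In a functional assay on D-38 cells (Homo sapiens) for cytotoxicity (on this read-out lower numbers stand for an effect already at smaller amounts and higher numbers for an effect only at larger amounts of compound), compound 1 gives only a limit, > 100 uM. Compound 2 `NC1CC(n2cc(Br)c(=O)[nH]c2=O)OC1CO` carries bromo. In this assay compound 2 likewise reaches only a limit, > 100 uM. Compound 3 `NC1CC(n2cc(Cl)c(=O)[nH]c2=O)OC1CO` carries chloro. For compound 3 the read-out again stops at a limit, > 100 uM. Because all three sit at the limit of > 100 uM in this assay, at which 3 of the 3 values shown sit, the steps between them cannot be read: a step that the two limits leave unreadable from compound 1 to compound 2, a step that the two limits leave unreadable from compound 1 to compound 3 and a step that the two limits leave unreadable from compound 2 to compound 3. Compound 3 thus stands at the same limit as the other two, and no number places it apart from them.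

Compound 4 `NC1CC(n2cc(F)c(=O)[nH]c2=O)OC1CO` is the next member: fluoro in place of chloro on an aromatic carbon. All three measured steps bear on this change; each swaps one halogen for another on the same aromatic carbon, yet none has a readable size. Among the compounds with values here, nothing among the measured compounds points to an effect at smaller amounts, so compound 4 is expected to stay near the limit, an expected step that the limit leaves unreadable from compound 3 to compound 4. The estimate for compound 4 is 150 uM, within 50 uM to 500 uM, with a high chance that only a limit is reported again.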

Compound 4, concentration for half-maximal effect: > 100 uM
Compound 4: a limit, no number (the forecaster's own chance of this, stated with the estimate: 85%); the middle value is on the limit's open side.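

In this assay compound 4 gives > 100 uM, which is a limit and not a number. Within the data shown here, no step linking compound 4 to compound 1, compound 2 or compound 3 can be read, because all four stop at the same limit: the limit of > 100 uM in this assay, at which 4 of the 4 values shown sit. Going by these compounds, whether swapping one halogen for another changes the effect at all remains open.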